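Fluoro in Place of Chloro: Cytotoxicity in J774 Cells

The compounds below may be only part of what the source reports. "The series", "measured", "known", "first", "only" and "open" are said of these compounds alone.

Measured in an ADME assay on J774 cells (Mus musculus) for cytotoxicity, read by MTT assay, with a stated time of 48 h, tested at 50 ug/mL; on this read-out higher numbers stand for a weaker effect at the one concentration tested and lower numbers for a stronger effect:
compound 1 `O=C(N/N=C/c1ccccc1Cl)c1cnccn1` gives 70%
compound 2 `O=C(N/N=C/c1cccc(Cl)c1)c1cnccn1` gives 100%
compound 3 `O=C(N/N=C/c1ccccc1F)c1cnccn1` gives 100%

Compound 1 and compound 3 share a core and differ by fluoro in place of chloro on an aromatic carbon; this gave a number 30 percentage points higher from compound 1 to compound 3 (beyond the scatter). Compound 2 has the same atoms as compound 1 joined differently, and the difference between the two cores is not broken down here. Compound 2 and compound 3 stand level at the digits printed, so no order between them is claimed.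

Compound 4 `O=C(N/N=C/c1cccc(F)c1)c1cnccn1` has not been measured. It differs from compound 2 by fluoro in place of chloro on an aromatic carbon. This is the same kind of change as that from compound 1 to compound 3, but the place differs: there the fluoro stands ortho to a large group, here it stands meta to a large group. The earlier step was upward, but compound 2 already gives 100%, which leaves little room for a further rise. The step from compound 2 to compound 4 is therefore expected to be a number 2 percentage points lower from compound 2 to compound 4 (within the scatter). Compound 4 is estimated at 98%, in a range from 85% to 110%.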

Compound 4, a percentage reported as activity, at one concentration (the size of the read-out at that concentration, not a potency): 49%
Beside the measured number, compound 4's estimate is 49 percentage points above it; measured number outside the range, below it.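

In this assay, fluoro in place of chloro on an aromatic carbon did not carry over from one core to the other, and the two steps run in opposite directions: the same change on two cores in this assay, a number 30 percentage points higher (beyond the scatter) from compound 1 to compound 3 and a number 51 percentage points lower (beyond the scatter) from compound 2 to compound 4, 81 percentage points apart, beyond the scatter of two such steps The new step, with the change meta to a large group, is a number 51 percentage points lower from compound 2 to compound 4 (beyond the scatter), so on this read-out the fluoro compound of this pair shows the stronger effect, the reverse of what the earlier pair showed. Within the data shown here, this shows that the outcome of the change in one pair cannot be assumed for the other, but it rests on only two pairs and does not show why they part, nor does it give a rule for any further core.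

The compounds shown leave open how a methoxy group, an amine or a nitrile on the same aromatic carbon would read in this assay. They also leave open whether either direction of the fluoro change would recur on a third core.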